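Alkoxy chain variation on the pyridine-linked carbamate series

The source may hold more compounds than are shown below. What is called first, only, known or untested is meant among the compounds shown, and "the series" means these compounds.

Measured so far:
- compound 1, `CCc1sc(CCc2cc(OC)cc(NCc3cc(Cl)cc(NC(=O)OC(C)C)c3)n2)nc1C`: 234 nM
- compound 2, `CCCCOc1cc(CCc2nc(C)c(CC)s2)nc(NCc2cc(Cl)cc(NC(=O)OC(C)C)c2)c1`: 16 nM
- compound 3, `CC/C=C\CCOc1cc(CCc2nc(C)c(CC)s2)nc(NCc2cc(Cl)cc(NC(=O)OC(C)C)c2)c1`: 4.7 nM

All three values come from an assay on cells for binding affinity to Neuropeptide Y receptor type 1 (Homo sapiens); a higher number here means a weaker inhibitor, a lower number a stronger inhibitor. Compound 3 is the strongest of the three; its steps to both others lie beyond the scatter, a 50-fold lower number from compound 1 to compound 3 (1.70 log units; beyond the scatter) and a 3.4-fold lower number from compound 2 to compound 3 (0.53 log units; beyond the scatter).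

Compound 4, `CCc1sc(CCc2cc(OC(C)C)cc(NCc3cc(Cl)cc(NC(=O)OC(C)C)c3)n2)nc1C`, differs from compound 3 in one place: isopropyl in place of hex-3-en-1-yl on an oxygen on an aromatic ring. The relevant measured steps all concern the same oxygen on the aromatic ring: a 15-fold lower number from compound 1 to compound 2 (1.17 log units; beyond the scatter), a 3.4-fold lower number from compound 2 to compound 3 (0.53 log units; beyond the scatter). Larger groups there have given lower numbers; isopropyl sits between methyl and butyl in size, so a step back toward compound 1 is expected, short of its value.

Compound 4 is therefore expected to give 60 nM, within 20 nM to 180 nM, meaning a 13-fold higher number from compound 3 to compound 4 (1.11 log units; beyond the scatter).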

Compound 4, half-maximal inhibitory concentration: 12 nM
Beside the measured number, compound 4's estimate is 5.0-fold (0.70 log units) above it; the measured number lies below the stated range.
By their numbers in this assay, from the lowest: compound 3; then compounds 4 and 2 (each within the scatter of the next); then compound 1.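

In this assay, isopropyl on this oxygen already captures most of the gain over methyl (a 20-fold lower number from compound 1 to compound 4 (1.29 log units; beyond the scatter)), and it cannot be separated from butyl (a 1.3-fold lower number from compound 2 to compound 4 (0.12 log units; within the scatter)), so compounds 2 and 4 break any simple rise in strength with each added carbon. Hex-3-en-1-yl remains distinct from isopropyl (a 2.6-fold higher number from compound 3 to compound 4 (0.41 log units; beyond the scatter)), so the longer unsaturated chain still offers a real, though modest, edge. No available data explain these differences.

Open, as far as these compounds go, is whether saturated hexyl would match compound 3, separating chain length from the double bond. Also open, from the compounds shown here alone, is how cyclopentyl or a chain ending in an amine would fare on this oxygen.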